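The source may report more compounds than this note shows. Statements on the series, on what has been measured and on what is new or still open speak of the compounds shown alone.

Compound 1 `CC(O)c1cn(CCNc2nonc2/C(=N/O)Nc2ccc(F)c(Br)c2)nn1` carries the shared core with a 1-hydroxyethyl group on the triazole carbon; in an assay on isolated protein for inhibition of Indoleamine 2,3-dioxygenase 1 (Homo sapiens) (on this read-out higher numbers stand for weaker inhibition and lower numbers for stronger inhibition), compound 1 gives 53 nM. Compound 2 `CC(C)(O)c1cn(CCNc2nonc2/C(=N/O)Nc2ccc(F)c(Br)c2)nn1` differs from it by methyl in place of hydrogen on a saturated chain carbon bound to an aromatic carbon, an oxygen on a saturated carbon and a saturated chain carbon, and this step is a 2.2-fold higher number from compound 1 to compound 2 (0.34 log units; beyond the scatter), compound 2 giving 115 nM in this assay. Compound 3 `CC(OCCO)c1cn(CCNc2nonc2/C(=N/O)Nc2ccc(F)c(Br)c2)nn1` differs from compound 1 by 2-hydroxyethyl in place of hydrogen on an oxygen on a saturated carbon, a step of a 2.5-fold higher number from compound 1 to compound 3 (0.40 log units; beyond the scatter), and compound 3 gives 134 nM in this assay. Between compound 2 and compound 3 the change is a 1.2-fold higher number from compound 2 to compound 3 (0.07 log units; within the scatter), so their two values are not distinguished.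

Compound 4 `CC(C)(OCCO)c1cn(CCNc2nonc2/C(=N/O)Nc2ccc(F)c(Br)c2)nn1` has not yet been measured. It differs from compound 3 by methyl in place of hydrogen on a saturated chain carbon bound to an aromatic carbon, an oxygen on a saturated carbon and a saturated chain carbon, which is the same change already seen from compound 1 to compound 2, at a place that reads word for word the same. Because that earlier step was a 2.2-fold higher number from compound 1 to compound 2 (0.34 log units; beyond the scatter), a step of about the same size, a 2.1-fold higher number from compound 3 to compound 4 (0.32 log units; beyond the scatter), is expected for compound 4 in this assay. Compound 4 is therefore estimated at 280 nM, with a range from 130 nM to 600 nM.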

Compound 4, half-maximal inhibitory concentration: 176 nM
Beside the measured number, compound 4's estimate is 1.6-fold (0.20 log units) above it, and the stated range covers the measured number.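

Carrying the methyl change to the second core in this assay gives a 1.3-fold higher number from compound 3 to compound 4 (0.12 log units; within the scatter), and this step does not differ from the earlier one: the same change on two cores in this assay, a 2.2-fold higher number (0.34 log units; beyond the scatter) from compound 1 to compound 2 and a 1.3-fold higher number (0.12 log units; within the scatter) from compound 3 to compound 4, 1.7-fold (0.22 log units) apart, within the scatter of two such steps. The 2-hydroxyethyl change, carried to the core of compound 2, gives a 1.5-fold higher number from compound 2 to compound 4 (0.18 log units; within the scatter), and it too does not differ from its earlier step: the same change on two cores in this assay, a 2.5-fold higher number (0.40 log units; beyond the scatter) from compound 1 to compound 3 and a 1.5-fold higher number (0.18 log units; within the scatter) from compound 2 to compound 4, 1.7-fold (0.22 log units) apart, within the scatter of two such steps. Taken together, the two changes amount to a 3.3-fold higher number from compound 1 to compound 4 (0.52 log units; beyond the scatter), which agrees with each change carrying over, but it does not show that either step is fixed in size, since each is seen on only two cores and the later step of each pair lies within the scatter.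

The compounds shown leave open whether the methyl step would hold if an amine or a carboxylic acid stood in place of the terminal hydroxyl of the 2-hydroxyethyl group, or if a longer chain replaced that group. They also leave open whether either step would persist with chlorine in place of the bromine on the shared core.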